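The source may hold more compounds than are shown below. What is called first, only, known or untested is meant among the compounds shown, and "the series" means these compounds.

Three compounds sharing one core differ only in the group on their outer phenyl ring: compound 1 `COc1cc(-n2cnc3ccc(-c4ccc(C(F)(F)F)cc4)cc32)cc(OC)c1OC` carries trifluoromethyl, compound 2 `COc1ccc(-c2ccc3ncn(-c4cc(OC)c(OC)c(OC)c4)c3c2)cc1` carries methoxy and compound 3 `COc1cc(-n2cnc3ccc(-c4ccccc4)cc32)cc(OC)c1OC` carries hydrogen. In a functional assay on SGC-7901 cells (Homo sapiens) for antiproliferative activity, read by MTT assay, with a stated time of 72 h (on this read-out lower numbers stand for stronger inhibition and higher numbers for weaker inhibition), compound 1 gives 890 nM, compound 2 gives 82 nM and compound 3 gives 290 nM, so compound 3 stands second highest of the three, nearer to compound 1 than to compound 2. The change to compound 4 `COc1cc(-n2cnc3ccc(-c4ccc(O)cc4)cc32)cc(OC)c1OC` is hydroxy in place of hydrogen on an aromatic carbon. Within the data shown here, the steps that bear on it are a 3.5-fold higher number from compound 2 to compound 3 (0.55 log units; beyond the scatter) and a 3.1-fold lower number from compound 1 to compound 3 (0.49 log units; beyond the scatter). Because compound 2 gives 82 nM with methoxy where compound 4 bears hydroxy, a modest step toward a lower number is expected, namely a 1.9-fold lower number from compound 3 to compound 4 (0.29 log units; within the scatter). Compound 4 is therefore estimated at 150 nM, within a range from 60 nM to 400 nM.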

Compound 4, half-maximal inhibitory concentration: > 10000 nM
Compound 4: no number, only a limit; the forecaster's own chance of this, stated with the estimate: 2%; middle value at least 66-fold (1.82 log units) away from the limit.
By their numbers in this assay, from the lowest: compound 2; then compound 3; then compound 1. At a limit, above all of these: compound 4.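

Compound 4 gives no number, only a limit: the limit of > 10000 nM in this assay, at which 1 of the 4 values shown sits.

At this place, para to a large group, hydroxy behaves very differently from hydrogen, with an at least 34-fold higher number from compound 3 to compound 4 (1.53 log units; beyond the scatter), and removing the methyl from the oxygen of methoxy gives an at least 120-fold higher number from compound 2 to compound 4 (2.08 log units; beyond the scatter). Even trifluoromethyl, which gave the highest number among the earlier compounds, compares favourably, with an at least 11-fold higher number from compound 1 to compound 4 (1.05 log units; beyond the scatter).

Still open, as far as these compounds go, is whether an amine or a carboxylic acid at this place would fare like hydroxy, and whether an ethoxy group would fare like methoxy. Four groups at one place give no cause for the loss.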